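The source may hold more compounds than are shown below. What is called first, only, known or untested is meant among the compounds shown, and "the series" means these compounds.

Compound 3 `COc1ccc(-c2cn3cc(C4=CCN(C(=O)c5ccc(Cl)cc5)CC4)ccc3n2)cc1OC` belongs to a small set of three close relatives built on one shared core, differing only in the group attached to the amide-type nitrogen in the ring. In a functional assay on B16-F10 cells (Mus musculus) for antiproliferative activity, read by MTT assay, with a stated time of 48 h (a lower number here means a stronger inhibitor, a higher number a weaker inhibitor), compound 3 gives 15300 nM, the highest of the three numbers shown, although it sits close to the others: compound 1 `COc1ccc(-c2cn3cc(C4=CCN(S(=O)(=O)CCc5ccccc5)CC4)ccc3n2)cc1OC` gives 8080 nM, and compound 2 `COc1ccc(-c2cn3cc(C4=CCN(C(=O)c5ccccc5C(F)(F)F)CC4)ccc3n2)cc1OC` gives 8110 nM. The steps of a 1.9-fold higher number from compound 1 to compound 3 (0.28 log units; within the scatter) and a 1.9-fold higher number from compound 2 to compound 3 (0.28 log units; within the scatter) are both within the scatter, as is a 1.0-fold higher number from compound 1 to compound 2 (0.00 log units; within the scatter), so none of these three compounds can be called stronger or weaker than another.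

Compound 4 `COc1ccc(-c2cn3cc(C4=CCN(C(=O)C(C)(C)C)CC4)ccc3n2)cc1OC` has not yet been measured. It differs from compound 3 by tert-butyl in place of 4-chlorophenyl on a carbonyl carbon. Going by the values given here, the only measured step at the same place is the one from compound 2 to compound 3, where one aromatic ring replaced another on the carbonyl carbon with no movement beyond the scatter. Among the compounds with values here, no measured pair trades an aromatic ring for a tert-butyl group, so the data give no direct guide. Given that every measured step so far stayed within the scatter, compound 4 is expected to remain near compound 3, with an expected step of a 1.0-fold lower number from compound 3 to compound 4 (0.01 log units; within the scatter). Compound 4 is therefore estimated at 15000 nM, within a range from 5000 nM to 45000 nM.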

Compound 4, half-maximal inhibitory concentration: 7100 nM
Compound 4: the middle estimate sits 2.1-fold (0.32 log units) above what was measured; the range from low to high includes it.
By their numbers in this assay, from the lowest: compounds 4, 1, 2 and 3 (each within the scatter of the next, the first and the last beyond it).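

In this assay the group on the carbonyl carbon now shows a step beyond the scatter, though only a modest one: a 2.2-fold lower number from compound 3 to compound 4 (0.33 log units; beyond the scatter), as tert-butyl, with no ring and 4 heavy atoms, replaces 4-chlorophenyl, with one six-membered aromatic ring and 7 heavy atoms. Going by these compounds alone, the other two new steps, a 1.1-fold lower number from compound 2 to compound 4 (0.06 log units; within the scatter) and a 1.1-fold lower number from compound 1 to compound 4 (0.06 log units; within the scatter), stay within the scatter, so compound 3 is the only measured compound that can be separated from compound 4, and an aromatic ring on this carbonyl carbon is not required to reach the numbers of compound 1 and compound 2. Nothing in the data shown explains why this change moves the number.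

On these data alone, it remains open whether the chlorine matters, which plain phenyl on the same carbonyl carbon could test, and whether methyl or cyclohexyl there would fall in line with tert-butyl. As far as these compounds go, it is also open whether a group carrying an amine or a carboxylic acid at this position would move the number further than any step seen so far.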